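A few compounds are considered here, and "the series" means these few. Any claim that something is new, unique, unknown or untested is made for them only; others in the source may bear on it.

In a functional assay on HL-60 cells (Homo sapiens) for antiproliferative activity, with a stated time of 72 h (on this read-out higher numbers stand for weaker inhibition and lower numbers for stronger inhibition), compound 1 `Nc1ncnn2c([C@@H]3O[C@H](CO)[C@@H](O)[C@H]3O)cc(C#CC3CC3)c12`, which carries cyclopropyl on the triple bond, gives 40 nM. Compound 2 `Nc1ncnn2c([C@@H]3O[C@H](CO)[C@@H](O)[C@H]3O)cc(C#Cc3cccs3)c12`, with thiophen-2-yl there, gives > 100000 nM, which is a limit of the assay and not a number. Compound 3 `Nc1ncnn2c([C@@H]3O[C@H](CO)[C@@H](O)[C@H]3O)cc(C#Cc3ccccc3)c12`, with phenyl there, gives > 100000 nM, again a limit. Compound 3 therefore stands at the limit of > 100000 nM in this assay, at which 2 of the 3 values shown sit.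

Compound 4 `Cc1ccccc1-c1cc([C@@H]2O[C@H](CO)[C@@H](O)[C@H]2O)n2ncnc(N)c12` has 2-methylphenyl in place of the 2-phenylethynyl of compound 3, on an aromatic carbon of the shared core: 2-methylphenyl in place of 2-phenylethynyl on an aromatic carbon.

The nearest evidence is an at least 2500-fold higher number from compound 1 to compound 3 (3.39 log units; beyond the scatter), alongside an at least 2500-fold higher number from compound 1 to compound 2 (3.39 log units; beyond the scatter). Both were large and both replaced cyclopropyl with an aromatic ring. Between the two aromatic groups there is a step that the two limits leave unreadable from compound 2 to compound 3. None of these steps removes the triple bond, so they bear on compound 4 only indirectly. Its aromatic ring suggests a result close to compound 3 at > 100000 nM, with no large gain in this assay.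

The expected result is an at least 2.5-fold lower number from compound 3 to compound 4 (0.39 log units; beyond the scatter), and it may not be readable at all. Compound 4 is estimated at 40000 nM, with an expected range of 2000 nM to 100000 nM.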

Compound 4, half-maximal inhibitory concentration: 48400 nM
Compound 4: the middle estimate sits 1.2-fold (0.08 log units) below what was measured, and the stated range covers the measured number.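

In this assay, compound 4 shows that an aromatic ring set directly on this aromatic carbon, without a triple bond, gives a readable number, with an at least 2.0-fold lower number from compound 3 to compound 4 (0.31 log units; beyond the scatter) and an at least 2.0-fold lower number from compound 2 to compound 4 (0.31 log units; beyond the scatter). Both steps are only bounds, as each starts from a limit of the assay rather than a number: the limit of > 100000 nM in this assay, at which 2 of the 4 values shown sit. Removing the triple bond does not bring back the level of the cyclopropyl compound, however, with a 1200-fold higher number from compound 1 to compound 4 (3.08 log units; beyond the scatter), so a 2-methylphenyl group here stays far weaker than a 2-cyclopropylethynyl group.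

The compounds shown leave open how much of the change belongs to losing the triple bond and how much to the methyl group on the ring, which a plain phenyl on this carbon would separate. They also leave open whether an aminomethyl or a longer alkyl chain on the triple bond would stay near compound 1.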